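From a branched to a straight chain at the amine

The source may hold more compounds than are shown below. What is called first, only, known or untested is meant among the compounds shown, and "the series" means these compounds.

Among the measured compounds shown here, compound 3 `Cc1c(NCC(C)C)c(=O)n(-c2ccccc2)c(=O)n1C` gives 1.48 in a physicochemical assay for lipophilicity (on this read-out higher numbers stand for higher lipophilicity and lower numbers for lower lipophilicity), the lowest of the three numbers measured so far; compound 1 `CCN(CC)c1c(C)n(CC)c(=O)n(-c2ccccc2)c1=O` gives 2.2 and compound 2 `Cc1c(N2CCCC2)c(=O)n(-c2ccccc2)c(=O)n1C` gives 2.26, each of them higher than compound 3 by more than the scatter. For the measured compounds named here, the only measured step between compounds differing in one place, a number 0.78 log units lower from compound 2 to compound 3 (beyond the scatter), concerns isobutylamino in place of pyrrolidin-1-yl and does not bear on the present change. Compound 4 `CCCCNc1c(C)n(C)c(=O)n(-c2ccccc2)c1=O` differs from compound 3 by propyl in place of isopropyl on a saturated chain carbon bound to a nitrogen on an aromatic ring, read one bond further out as isobutylamino to butylamino. Going by the values given here, no measured step tests this change, so compound 4 is expected to show a step of a number 0.12 log units higher from compound 3 to compound 4 (within the scatter) lying within the scatter. Compound 4 is therefore estimated at 1.6, with a range from 1.3 to 1.9.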

Compound 4, partition coefficient: 1.69
For compound 4 the middle estimate is 0.09 log units below the measured one; low and high end bracket the measured number.
By their numbers in this assay, from the lowest: compounds 3 and 4 (each within the scatter of the next); then compounds 1 and 2 (each within the scatter of the next).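

Moving from a branched to a straight chain at this position gives a number 0.21 log units higher from compound 3 to compound 4 (within the scatter) in this assay, so this read-out does not separate isobutylamino from butylamino. With a number 0.57 log units lower from compound 2 to compound 4 (beyond the scatter) as a second step, the drop seen on leaving pyrrolidin-1-yl is not confined to the isobutylamino compound, as butylamino shows it too. No evidence bears on the reason for these numbers.

The compounds shown leave open how a shorter chain such as ethylamino or a longer one such as hexylamino would read at this position. They also leave open whether a larger ring amine such as piperidin-1-yl would stay close to compound 2.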